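The source may report more compounds than this note shows. Statements on the series, on what has been measured and on what is new or still open speak of the compounds shown alone.

Measured in a functional assay on HEK293 cells for agonist activity at D(4) dopamine receptor (Homo sapiens), read by FLIPR; on this read-out lower numbers stand for smaller maximal responses and higher numbers for larger maximal responses:
compound 1 `Cc1cc(NC(=O)CN2CCC(c3cccc[n+]3[O-])CC2)ccc1F`, 75%
compound 2 `CSc1cccc(NC(=O)CN2CCC(c3cccc[n+]3[O-])CC2)c1`, 56%
compound 3 `Cc1cc(F)ccc1NC(=O)CN1CCC(c2cccc[n+]2[O-])CC1`, 84%

Compound 2 gives the lowest number of the three: the step of a number 19 percentage points lower from compound 1 to compound 2 (beyond the scatter) and the step of a number 28 percentage points higher from compound 2 to compound 3 (beyond the scatter) both lie beyond the scatter, whereas a number 9 percentage points higher from compound 1 to compound 3 (within the scatter) does not. Compound 4 `O=C(CN1CCC(c2cccc[n+]2[O-])CC1)Nc1cccc(C(F)(F)F)c1` differs from compound 2 by trifluoromethyl in place of methylsulfanyl on an aromatic carbon. The two steps that bear on this, a number 19 percentage points lower from compound 1 to compound 2 (beyond the scatter) and a number 28 percentage points higher from compound 2 to compound 3 (beyond the scatter), each exchange the whole aryl group on the amide nitrogen rather than a single substituent, and neither tests a trifluoromethyl group; both, however, leave compound 2 as the lower partner. A modest rise in this assay is therefore expected for compound 4, with a step within the scatter not excluded. For compound 4 a maximal response of 66% is estimated, between 50% and 84%, which means an expected step of a number 10 percentage points higher from compound 2 to compound 4 (within the scatter).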

Compound 4, largest response reached (reported as efficacy), in percent of the reference or control that the assay uses: 75%
The estimate for compound 4 lay 9 percentage points below the measured number; the range from low to high includes it.
By their numbers in this assay, from the lowest: compound 2; then compounds 1, 4 and 3 (each within the scatter of the next).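

In this assay, going by these compounds alone, trifluoromethyl in place of methylsulfanyl on this aromatic carbon gives a number 19 percentage points higher from compound 2 to compound 4 (beyond the scatter) and is the only step so far that exchanges one substituent while the rest of the aryl group stays the same. The maximal response at this position therefore changes with that substituent alone, not only with exchange of the whole aryl group. No measurement at hand explains this step.

Open, as far as these compounds go, is how a nitrile, a methoxy group or an amine on the same carbon compares with compound 2 and compound 4 in this read-out.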